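A few compounds are considered here, and "the series" means these few. Any claim that something is new, unique, unknown or untested is made for them only; others in the source may bear on it.

For the measured compounds named here, compound 1 (`NC1CCC(Nc2nc(NCc3ccc(Br)cc3)c3ncn(C4CCCC4)c3n2)CC1`) gives 1480 nM in a functional assay on G-361 cells (Homo sapiens) for inhibition, with a stated time of 72 h (a lower number here means a stronger inhibitor, a higher number a weaker inhibitor), and shares the upper end of the numbers known so far with compound 2 (`NC1CCC(Nc2nc(NCc3ccc(-c4ccccc4)nc3)c3ncn(C4CCCC4)c3n2)CC1`), which gives 895 nM in the same test. The step between them (a 1.7-fold lower number from compound 1 to compound 2 (0.22 log units; within the scatter)) lies within the scatter, so putting 6-phenylpyridin-3-yl in place of 4-bromophenyl shows no real change. Compound 3 (`NC1CCC(Nc2nc(NCc3ccc(-c4ccco4)nc3)c3ncn(C4CCCC4)c3n2)CC1`) stands apart at 97 nM with its 6-(furan-2-yl)pyridin-3-yl group, a large step from the bromo compound (a 15-fold lower number from compound 1 to compound 3 (1.18 log units; beyond the scatter)) and a modest one from the phenyl compound (a 9.2-fold lower number from compound 2 to compound 3 (0.97 log units; beyond the scatter)).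

Compound 4 (`NC1CCC(Nc2nc(NCc3ccc(-c4ccccc4O)cc3)c3ncn(C4CCCC4)c3n2)CC1`) has not yet been measured. It carries 2-hydroxyphenyl in place of bromo on an aromatic carbon, para to a large group (2-hydroxyphenyl in place of bromo on an aromatic carbon). Its added phenyl-type ring makes compound 2 the nearest guide (a 1.7-fold lower number from compound 1 to compound 2 (0.22 log units; within the scatter)), while compound 3 shows that a larger drop is possible at this end of the molecule (a 15-fold lower number from compound 1 to compound 3 (1.18 log units; beyond the scatter)). Going by the values given here, no measured compound carries a hydroxy group, so the data say nothing direct about it. A modest move to a lower number is therefore expected in this assay, with the estimated change being a 3.0-fold lower number from compound 1 to compound 4 (0.47 log units; beyond the scatter) and a wide margin of doubt. The estimated value for compound 4 is 500 nM (expected range 120 nM to 1800 nM).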

Compound 4, half-maximal inhibitory concentration: 4150 nM
Compound 4: middle estimate off by 8.3-fold (0.92 log units), on the low side; measured number above the stated range.
By their numbers in this assay, from the lowest: compound 3; then compounds 2 and 1 (each within the scatter of the next); then compound 4.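

In this assay, 2-hydroxyphenyl in place of bromo gives a step in the opposite direction to the other changes at this end of the molecule (a 2.8-fold higher number from compound 1 to compound 4 (0.45 log units; beyond the scatter)). Set beside the other two steps from compound 1 (a 1.7-fold lower number from compound 1 to compound 2 (0.22 log units; within the scatter); a 15-fold lower number from compound 1 to compound 3 (1.18 log units; beyond the scatter)), it shows that a second aromatic ring at this end does not by itself bring a lower number, since the three outcomes are no real change, a large drop and a modest rise. The position therefore tolerates added rings to differing degrees, and the identity of the ring and its substituents matters, but no measurement here offers an explanation for the rise.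

Compound 4 brings in the benzene ring and the hydroxy group together, so the compounds shown cannot separate what each contributes to the higher number. Plain phenyl in place of bromo would isolate the ring, 2-methoxyphenyl would test whether the hydroxy hydrogen matters, and furan-2-yl on this same benzene ring would show whether the lower number of compound 3 carries over without its pyridine ring.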